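The source may report more compounds than this note shows. Statements on the series, on what has been measured and on what is new or still open speak of the compounds shown alone.

Compound 1 `O=[N+]([O-])c1ccc(CN2CCC(n3cc(CC(OCc4cc(-c5ccccc5)no4)c4ccc(Br)cc4)nn3)CC2)cc1`: in a functional assay on HCT-116 cells (Homo sapiens) for cytotoxicity, with a stated time of 48 h (on this read-out higher numbers stand for weaker inhibition and lower numbers for stronger inhibition), compound 1 gives a limit, > 25000 nM.
Compound 2 `COc1ccc(-c2cc(COC(Cc3cn(C4CCN(Cc5ccc([N+](=O)[O-])cc5)CC4)nn3)c3ccc(Br)cc3)on2)cc1`: in this assay compound 2 gives a limit, > 25000 nM.
Compound 3 `N#Cc1ccc(-c2cc(COC(Cc3cn(C4CCN(Cc5ccc([N+](=O)[O-])cc5)CC4)nn3)c3ccc(Br)cc3)on2)cc1`: in this assay compound 3 gives a limit, > 25000 nM.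

Compound 3 thus stands where all measured members of the series stand, at the limit of > 25000 nM in this assay, at which 3 of the 3 values shown sit; no number separates it from the others. The three measured steps are all unreadable: a step that the two limits leave unreadable from compound 1 to compound 2, a step that the two limits leave unreadable from compound 1 to compound 3 and a step that the two limits leave unreadable from compound 2 to compound 3. None of them shows whether a change of the substituent on the outer phenyl ring moves the read-out at all.

Compound 4 `O=[N+]([O-])c1ccc(CN2CCC(n3cc(CC(OCc4cc(-c5cccc(Br)c5)no4)c4ccc(Br)cc4)nn3)CC2)cc1` carries the change (3-bromophenyl in place of 4-cyanophenyl on an aromatic carbon). This is again a change on the same outer phenyl ring that was varied in the measured steps, and those steps bear on it only in the sense that each of the three variants already tried stayed at the limit. There is no readable step from which a size or direction could be drawn, so the expectation for compound 4 is no change that the assay can report: the step of a number no higher from compound 3 to compound 4 (the limit leaves the size open) is expected to be unreadable, with compound 4 most likely returning another limit. For compound 4 the estimate in this assay is 25000 nM, with a range of 8000 nM to 100000 nM.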

Compound 4, half-maximal inhibitory concentration: > 25000 nM
Compound 4 ended at the assay's limit (the forecaster's own chance of this, stated with the estimate: 85%); the middle value lies on the limit itself.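

The steps linking compound 4 to compound 1, compound 2 and compound 3 cannot be read, because all four compounds share one limit: the limit of > 25000 nM in this assay, at which 4 of the 4 values shown sit.

The compounds shown leave open whether any substituent on the outer phenyl ring moves the read-out in this assay, and what actual half-maximal inhibitory concentration any of these four compounds has.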